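The source may hold more compounds than are shown below. What is called first, only, known or untested is meant among the compounds shown, and "the series" means these compounds.

Compound 1 `COc1ccc(-c2cc(-c3cccc(S(C)(=O)=O)c3)cnc2N)cn1` gives 7.6 mL.min-1.g-1 in an in vitro ADME assay on microsomes from liver (Homo sapiens) for metabolic stability; a lower number here means slower removal, a higher number faster removal of the compound.
Compound 2 `CNS(=O)(=O)c1ccc(-c2cnc(N)c(-c3ccc(OC)nc3)c2)cc1` gives 9.6 mL.min-1.g-1 in this assay.
Compound 3 `COc1ccc(-c2cc(-c3ccc(S(=O)(=O)NC4CC4)cc3)cnc2N)cn1` gives 15 mL.min-1.g-1 in this assay.

Among these three, compound 2 stands second highest, yet its gaps to compound 1 and to compound 3 both lie within the usual scatter, so no real order among them can be claimed. Compound 4 `COc1ccc(-c2cc(-c3ccc(NS(C)(=O)=O)cc3)cnc2N)cn1` differs from compound 2 in one place: methanesulfonamido in place of methylsulfamoyl on an aromatic carbon. Among the measured compounds shown here, the only measured step, a 1.6-fold higher number from compound 2 to compound 3 (0.19 log units; within the scatter), concerns the substituent on the sulfonamide nitrogen and stayed within the scatter; no measured step rearranges the group in the way seen here. With nothing pointing either way, no shift beyond the scatter is expected. Compound 4 is therefore estimated at 10 mL.min-1.g-1, with a range from 5 mL.min-1.g-1 to 20 mL.min-1.g-1, the expected step being a 1.0-fold higher number from compound 2 to compound 4 (0.02 log units; within the scatter).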

Compound 4, intrinsic clearance in microsomes: < 7 mL.min-1.g-1
Compound 4 ended at the assay's limit; the forecaster's own chance of this, stated with the estimate: 5%; middle value at least 1.4-fold (0.15 log units) from the limit.
By their numbers in this assay, from the lowest: compounds 1, 2 and 3 (each within the scatter of the next). At a limit, below all of these: compound 4.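

In this assay compound 4 is reported only as a limit of the assay, not as a number: the limit of < 7 mL.min-1.g-1 in this assay, at which 1 of the 4 values shown sits. With the same atoms joined differently, methanesulfonamido in place of methylsulfamoyl gives an at least 1.3-fold lower number from compound 2 to compound 4 (0.13 log units; that floor lies within the scatter), so this step alone does not establish a real change. Methanesulfonamido in place of cyclopropylsulfamoyl gives an at least 2.1-fold lower number from compound 3 to compound 4 (0.33 log units; beyond the scatter), the first step at this position to pass the scatter.

As far as these compounds go, the true size of both steps stays unknown. Also open, from the compounds shown here alone, is whether a longer chain in place of the methyl of methanesulfonamido, or a carboxylic acid at this position, would keep the number this low.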